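Turning the hydroxy group of compound 2 into methoxy

The compounds below may be only part of what the source reports. "The series", "measured", "known", "first", "only" and "open" are said of these compounds alone.

In a functional assay on HT-29 cells (Homo sapiens) for antiproliferative activity, read by MTT assay, with a stated time of 72 h (on this read-out lower numbers stand for stronger inhibition and higher numbers for weaker inhibition), compound 1 `C=CC(=O)Nc1nc(-c2ccccc2)cs1` gives 6600 nM. Compound 2 `C=CC(=O)Nc1nc(-c2ccccc2O)cs1` gives 16200 nM, the higher of the two numbers and so the weaker inhibition. Among the measured compounds shown here, the only measured step is a 2.5-fold higher number from compound 1 to compound 2 (0.39 log units; beyond the scatter), a modest change beyond the scatter, which came with hydroxy in place of hydrogen on an aromatic carbon. Compound 3 `C=CC(=O)Nc1nc(-c2ccccc2OC)cs1` alters that same hydroxy group: methyl in place of hydrogen on an oxygen on an aromatic ring. For the measured compounds named here, no hydroxy-to-methoxy step has been measured here, so the evidence is thin. Going by the values given here, the one guide is a 2.5-fold higher number from compound 1 to compound 2 (0.39 log units; beyond the scatter), which suggests a change of similar or smaller size. A partial return towards the lower number is expected in this assay, with an estimated 1.6-fold lower number from compound 2 to compound 3 (0.21 log units; within the scatter). The estimate for compound 3 is 10000 nM, with an expected range of 4000 nM to 25000 nM.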

Compound 3, half-maximal inhibitory concentration: > 30000 nM
Compound 3 was reported as a limit; the forecaster's own chance of this, stated with the estimate: 3%; middle value at least 3.0-fold (0.47 log units) away from the limit.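

In this assay, the reading for compound 3 is a limit of the assay and not a number: the limit of > 30000 nM in this assay, at which 1 of the 3 values shown sits. Putting methyl on the oxygen does not bring back the stronger inhibition seen without the hydroxy group, and the step reads an at least 1.8-fold higher number from compound 2 to compound 3 (0.26 log units; that floor lies within the scatter). The firmer comparison is with plain hydrogen on the aromatic carbon, where the step reads an at least 4.5-fold higher number from compound 1 to compound 3 (0.65 log units; beyond the scatter), so among the compounds shown, both hydroxy and methoxy on this carbon come with weaker inhibition than hydrogen.

Because of that limit, the order of hydroxy and methoxy remains unsettled. Also open, from the compounds shown here alone, is whether any group at this place can beat hydrogen, a question that an amine, a carboxylic acid or a single fluorine atom could help to answer.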